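From Acid to Hydroxypiperidine Amide: Expected Solubility

The compounds below may be only part of what the source reports. "The series", "measured", "known", "first", "only" and "open" are said of these compounds alone.

Compound 1 (`N#Cc1ccc(-c2cnc(N)c(-c3ccc(N)nc3)n2)cc1`): < 5000 nM
Compound 2 (`Nc1ncc(-c2ccc(C(=O)N3CCC(N)C3)cc2)nc1-c1ccc(C(F)(F)F)cc1`): 102000 nM
Compound 3 (`Nc1ncc(-c2ccc(C(=O)O)cc2)nc1-c1ccc(C(F)(F)F)cc1`): 95000 nM

Of the compounds shown here, three have so far been measured in a physicochemical assay for solubility, read by HPLC, using the shake flask method, in phosphate buffer, with a stated time of 2 h, at pH 6.5; on this read-out higher numbers stand for higher solubility and lower numbers for lower solubility. For compound 1 the value < 5000 nM is a limit of this assay and not a number. Compound 2 gives 102000 nM in this assay. Going by the values given here, compound 3 gives 95000 nM in this assay; of the two numbers it stands lowest, with compound 2 nearest, and the single measured step, a 1.1-fold lower number from compound 2 to compound 3 (0.03 log units; within the scatter), lies within the scatter.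

Compound 4 (`Nc1ncc(-c2ccc(C(=O)N3CCC(O)CC3)cc2)nc1-c1ccc(C(F)(F)F)cc1`) has not yet been measured in this assay. It differs from compound 3 by 4-hydroxypiperidin-1-yl in place of hydroxy on a carbonyl carbon. Among the compounds with values here, the only step that bears on this change is the one from the amide to the acid, which moved the number no further than the scatter; the group that enters here, however, is a different one, for which no measurement exists. The step of a 2.1-fold lower number from compound 3 to compound 4 (0.32 log units; beyond the scatter) is therefore expected to be small, possibly toward a lower number. For compound 4 the estimated value is 45000 nM, expected to lie between 12000 nM and 130000 nM.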

Compound 4, solubility: 19000 nM
For compound 4 the middle estimate is 2.4-fold (0.37 log units) above the measured one, and the stated range covers the measured number.
By their numbers in this assay, from the lowest: compound 4; then compounds 3 and 2 (each within the scatter of the next). At a limit, below all of these: compound 1.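

In this assay, the group on the carbonyl carbon whose other neighbour is an aromatic carbon proves able to move the number: 4-hydroxypiperidin-1-yl in place of hydroxy gives a 5.0-fold lower number from compound 3 to compound 4 (0.70 log units; beyond the scatter). The earlier compounds had shown no such movement at this place, with only a 1.1-fold lower number from compound 2 to compound 3 (0.03 log units; within the scatter), and 4-hydroxypiperidin-1-yl in place of 3-aminopyrrolidin-1-yl likewise gives a 5.4-fold lower number from compound 2 to compound 4 (0.73 log units; beyond the scatter), so the new amide stands apart from both earlier groups. Nothing measured here gives a cause for these steps.

The compounds shown leave open whether the hydroxy on the ring or the six-membered ring itself goes with the lower number. On these data alone, a plain piperidin-1-yl or a morpholin-4-yl on the same carbonyl carbon would bear on that question, and how either would read remains unknown.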